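From compound 3 to compound 4: losing the amino group

The source may hold more compounds than are shown below. What is called first, only, known or untested is meant among the compounds shown, and "the series" means these compounds.

Values in a functional assay on MDA-MB-231 cells (Homo sapiens) for cytotoxicity, read by MTT assay, with a stated time of 48 h; a higher number here means a weaker inhibitor, a lower number a stronger inhibitor:
- Compound 1 `Nc1ccc(NC(=O)NCCCCC(c2ccc(F)cc2)c2ccc(F)cc2)cc1`: > 20000 nM, a limit and not a number
- Compound 2 `O=C(NCCCCC(c1ccc(F)cc1)c1ccc(F)cc1)Nc1ccc(C(F)(F)F)cc1`: 2780 nM
- Compound 3 `Nc1cc(NC(=O)NCCCCC(c2ccc(F)cc2)c2ccc(F)cc2)ccc1Cl`: 9240 nM

Of the two true numbers, compound 3 has the higher, so it is the weaker inhibitor of that pair in this assay. Compound 4 `Cc1cc(Cl)ccc1NC(=O)NCCCCC(c1ccc(F)cc1)c1ccc(F)cc1` differs from it in one place, on an amide-type nitrogen: 4-chloro-2-methylphenyl in place of 3-amino-4-chlorophenyl on an amide-type nitrogen. Here 4-chloro-2-methylphenyl stands in place of 3-amino-4-chlorophenyl, so the amino group is gone.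

Among the measured compounds shown here, three measured steps bear on this change. Trifluoromethyl in place of amino gave an at least 7.1-fold lower number from compound 1 to compound 2 (0.85 log units; beyond the scatter). Moving to 3-amino-4-chlorophenyl gave an at least 2.1-fold lower number from compound 1 to compound 3 (0.33 log units; beyond the scatter), while the same group in place of 4-(trifluoromethyl)phenyl gave a 3.3-fold higher number from compound 2 to compound 3 (0.52 log units; beyond the scatter). Thus compound 2, the one compound without an amino group, has the lowest number, though no measured compound carries the methyl. A modest step downward is therefore expected, and the expected size is a 2.3-fold lower number from compound 3 to compound 4 (0.36 log units; beyond the scatter). For compound 4 the estimate is 4000 nM, with an expected range from 1500 nM to 11000 nM.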

Compound 4, half-maximal inhibitory concentration: > 20000 nM
Compound 4: no number, only a limit (the forecaster's own chance of this, stated with the estimate: 8%); at least 5.0-fold (0.69 log units) between middle value and limit.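

In this assay compound 4 gives > 20000 nM, a limit and not a number. Taking away the amino group brought no gain here, as the result is an at least 2.1-fold higher number from compound 3 to compound 4 (0.33 log units; beyond the scatter); compound 2 also has no amino group, yet the other new step is an at least 7.1-fold higher number from compound 2 to compound 4 (0.85 log units; beyond the scatter), so among these compounds the lack of an amino group does not alone give a low number. The step linking compound 1 and compound 4 cannot be read, as both sit at the same limit: the limit of > 20000 nM in this assay, at which 2 of the 4 values shown sit.

This change removes the amino group and adds a methyl in one move, so the compounds shown cannot say which of the two matters. Going by these compounds, a plain 4-chlorophenyl group, with neither amino nor methyl, would separate them, and how far compound 4 lies past its limit remains unknown.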